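Replacing an ethyl with 4-fluorophenyl on an aryl ether chain

A few compounds are considered here, and "the series" means these few. Any claim that something is new, unique, unknown or untested is made for them only; others in the source may bear on it.

Measured so far in an ADME assay on KB cells (Homo sapiens) for cytotoxicity; on this read-out lower numbers stand for an effect already at smaller amounts and higher numbers for an effect only at larger amounts of compound:
- compound 1, `CCCCOc1c(OC)c(OC)cc2c1C(=O)[C@]1(OC)C=C[C@H]2N(C(=O)OC)N1C(=O)OC`, gives > 300 ug/mL, a limit of the assay
- compound 2, `CCCOc1c(OC)c(OC)cc2c1C(=O)[C@]1(OC)C=C[C@H]2N(C(=O)OCC)N1C(=O)OCC`, gives > 300 ug/mL, a limit of the assay
- compound 3, `COc1cc2c(c(O)c1OC)C(=O)[C@]1(OC)C=C[C@H]2N(C(=O)OCC(C)C)N1C(=O)OCC(C)C`, gives > 300 ug/mL, a limit of the assay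

Within the data shown here, compound 2 thus stands where every value so far stands: the limit of > 300 ug/mL in this assay, at which 3 of the 3 values shown sit. Among the measured compounds shown here, none of the three compounds gave a number, so no step between measured compounds is known.

Compound 4, `CCOC(=O)N1[C@@H]2C=C[C@@](OC)(C(=O)c3c2cc(OC)c(OC)c3OCc2ccc(F)cc2)N1C(=O)OCC`, is not yet measured. It differs from compound 2 in one place: 4-fluorophenyl in place of ethyl on a saturated chain carbon bound to an oxygen on an aromatic ring. With every known value at the same limit, no step beyond the usual scatter is expected.

Compound 4 is expected to give 300 ug/mL, within 100 ug/mL to 600 ug/mL, an expected step of a number no higher from compound 2 to compound 4 (the limit leaves the size open).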

Compound 4, concentration for half-maximal effect: 51.8 ug/mL
Compound 4: the middle estimate sits 5.8-fold (0.76 log units) above what was measured; measured number outside the range, below it.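

In this assay, among these compounds, 4-fluorophenyl in place of ethyl on this chain gives an at least 5.7-fold lower number from compound 2 to compound 4 (0.76 log units; beyond the scatter), so this place on the shared core can move the read-out, something the earlier compounds could not show. For compound 2, > 300 ug/mL is a limit of the assay. Compound 4 alone gives a real number here, while the others stay at that limit: the limit of > 300 ug/mL in this assay, at which 3 of the 4 values shown sit.

From the compounds shown here alone, whether the change comes from the aromatic ring or from its fluorine stays open; a plain phenyl on the same chain would separate the two. The compounds shown also leave open how an amine in this place would behave.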